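A few compounds are considered here, and "the series" means these few. Any claim that something is new, unique, unknown or untested is made for them only; others in the source may bear on it.

Of the compounds shown here, two of one family have been measured so far, and they share the same core, an amide carrying a free aniline amine on one side and a benzyl sulfide on the other. Compound 1 `Nc1ccccc1NC(=O)c1ccc(CSc2nccc(C(F)(F)F)n2)cc1` carries a trifluoromethyl-bearing pyrimidine on the sulfur, while compound 2 `Nc1ccccc1NC(=O)c1ccc(CSc2cccc(F)c2)cc1` carries a fluorinated phenyl ring there. In a functional assay on HCT-116 cells (Homo sapiens) for inhibition, read by CCK-8 assay, with a stated time of 72 h, tested at 8 uM (a lower number here means less inhibition of growth, a higher number more inhibition of growth at the concentration tested), compound 1 gives 93.1%, and in this assay compound 2 gives 81.4%. Compound 2 thus stands at the lower of the two numbers, and the gap to compound 1 is wider than the usual scatter of this kind of measurement.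

Compound 3 `Nc1ccccc1NC(=O)c1ccc(CSc2ccc(Cl)cc2)cc1` is the next one to be tested. It differs from compound 2 in a single place: 4-chlorophenyl in place of 3-fluorophenyl on a sulfur. Within the data shown here, no pair of measured compounds shows what such a swap of one halogenated phenyl ring for another does here, so the expectation rests on compound 2 alone. Compound 3 is expected to stay close to compound 2, with a step of a number 0.6 percentage points higher from compound 2 to compound 3 (within the scatter) that lies within the scatter. Compound 3 is estimated to give 82%, somewhere between 66% and 93%.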

Compound 3, percent growth inhibition at one concentration: 76.6%
Estimate against measurement, compound 3: 5.4 percentage points above, and the stated range covers the measured number.
By their numbers in this assay, from the lowest: compounds 3 and 2 (each within the scatter of the next); then compound 1.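

In this assay, putting 4-chlorophenyl in place of 3-fluorophenyl on a sulfur gives a number 4.8 percentage points lower from compound 2 to compound 3 (within the scatter), the first step measured between two compounds that differ in one place. This shows that this position accepts one halogenated phenyl ring in place of another without a difference that can be told from the scatter of the measurement. The halogen and its place on the ring change together in this swap, so the step shows only the outcome of the two changes combined, and no measured property of either group is available to explain that outcome.

A 3-chlorophenyl or a 4-fluorophenyl group on the sulfur would separate the identity of the halogen from its place on the ring, and those two effects remain unresolved here. Going by these compounds, it also remains open whether the halogen matters at all, and how an unsubstituted phenyl ring, or a phenyl ring carrying an amine or a carboxylic acid, would perform at this position.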